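This account rests on a few compounds, and the source may have more. Where it says the series, first, only, none or still open, it means among the compounds named here.

In a functional assay on DU-145 cells (Homo sapiens) for cytotoxicity, read by trypan blue exclusion, with a stated time of 96 h (on this read-out higher numbers stand for weaker inhibition and lower numbers for stronger inhibition), the measured compounds are:

- Compound 1 `COC(=O)C(Nc1cc(CS(=O)(=O)/C=C/c2c(OC)cc(OC)cc2OC)ccc1OC)c1ccccc1`: 75 nM
- Compound 2 `COC(=O)C(Nc1cc(CS(=O)(=O)/C=C/c2c(OC)cc(OC)cc2OC)ccc1OC)c1ccc(F)cc1`: 300 nM
- Compound 3 `COc1cc(OC)c(/C=C/S(=O)(=O)Cc2ccc(OC)c(NCCC(=O)O)c2)c(OC)c1`: 5000 nM

Compound 3 has the highest number of the three, at 5000 nM, making it the weakest inhibitor measured so far. Compound 4 `COc1cc(OC)c(/C=C/S(=O)(=O)Cc2ccc(OC)c(NC(F)(F)C(=O)O)c2)c(OC)c1` differs from it at one place: carboxy(difluoro)methyl in place of 2-carboxyethyl on a nitrogen on an aromatic ring. For the measured compounds named here, no measured step makes this exact exchange. The closest evidence comes from changes to the group on the same nitrogen, which gave large steps: a 67-fold higher number from compound 1 to compound 3 (1.82 log units; beyond the scatter) and a 17-fold higher number from compound 2 to compound 3 (1.22 log units; beyond the scatter). These show that the number in this assay can move strongly with this group, but neither step involves the incoming group. Going by the values given here, the only fluorine step, a 4.0-fold higher number from compound 1 to compound 2 (0.60 log units; beyond the scatter), was modest and raised the number, but it lies on an aromatic carbon rather than on this chain. With compound 3 at the top of the measured values, a moderate fall is expected, though with wide uncertainty. The expected change is a 6.3-fold lower number from compound 3 to compound 4 (0.80 log units; beyond the scatter). For compound 4, the estimated value is 800 nM, with an expected range from 60 nM to 6000 nM.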

Compound 4, half-maximal inhibitory concentration: 150 nM
Compound 4: the middle estimate sits 5.3-fold (0.73 log units) above what was measured; low and high end bracket the measured number.
By their numbers in this assay, from the lowest: compounds 1, 4 and 2 (each within the scatter of the next, the first and the last beyond it); then compound 3.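

In this assay, compound 3 and compound 4 both carry a carboxylic acid on the group at this nitrogen, yet exchanging 2-carboxyethyl for carboxy(difluoro)methyl gives a 33-fold lower number from compound 3 to compound 4 (1.52 log units; beyond the scatter), so the presence of that acid does not by itself set the number here. Compound 4 also stands level with the two compounds bearing a methoxycarbonyl group, with a 2.0-fold lower number from compound 2 to compound 4 (0.30 log units; within the scatter) and a 2.0-fold higher number from compound 1 to compound 4 (0.30 log units; within the scatter). The earlier compounds shown here alone linked the loss of those larger groups to a large rise in the number, and compound 4 shows that this rise does not always follow.

Going by these compounds, whether the change follows the fluorine atoms or the chain length stays open, as does how carboxymethyl or an amide would read on this nitrogen. No measurement shown here accounts for the result.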